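The source may hold more compounds than are shown below. What is called first, only, known or untested is meant among the compounds shown, and "the series" means these compounds.

Three compounds share one core and differ only in the side chain on a saturated chain carbon bound to an amide-type nitrogen and a carbonyl carbon. In a functional assay on the whole organism (Tail, strain ICR) with Mus musculus as the target, in the tail flick test, with a stated time of 150 min, at a dose of 25 umol/kg by the oral route (a lower number here means a weaker effect, a higher number a stronger effect of the compound at the dose given), compound 1 `N=C(N)NCCC[C@H](NC(=O)CN(c1ncnc2c1ncn2C1CCCCO1)C1CC1)C(=O)OCc1ccccc1` gives 19.6%, compound 2 `CC[C@H](C)[C@H](NC(=O)CN(c1ncnc2c1ncn2C1CCCCO1)C1CC1)C(=O)OCc1ccccc1` gives 16.4%, and compound 3 `NC(=O)C[C@H](NC(=O)CN(c1nc(Cl)nc2[nH]cnc12)C1CC1)C(=O)OCc1ccccc1` gives 13.5%. Compound 2 stands second highest of the three, and its gaps to compound 1 and to compound 3 both lie within the scatter, so the three cannot be ranked.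

Compound 4 `CC(C)(C)OC(=O)NCCCC[C@H](NC(=O)CN(c1ncnc2c1ncn2C1CCCCO1)C1CC1)C(=O)OCc1ccccc1` is not yet measured. It differs from compound 2 by 4-((tert-butoxycarbonyl)amino)butyl in place of sec-butyl on a saturated chain carbon bound to an amide-type nitrogen and a carbonyl carbon.

Among the measured compounds shown here, only one measured step bears on this change: a number 3.2 percentage points lower from compound 1 to compound 2 (within the scatter), where a different side chain was swapped at the same place and nothing beyond the scatter followed. For the measured compounds named here, no measured pair shows the group that enters in compound 4. From this single step, no move beyond the scatter is expected in this assay for compound 4, in either direction. The step from compound 2 to compound 4 is therefore expected to be a number 0.6 percentage points higher from compound 2 to compound 4 (within the scatter). Compound 4 is estimated to give 17%, within a range from 8% to 28%.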

Compound 4, a percentage reported as activity, at one dose (the size of the read-out at that dose, not a potency): 17.2%
For compound 4 the middle estimate is 0.2 percentage points below the measured one, and the stated range covers the measured number.
By their numbers in this assay, from the lowest: compounds 3, 2, 4 and 1 (each within the scatter of the next).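

In this assay, putting 4-((tert-butoxycarbonyl)amino)butyl in place of sec-butyl on this saturated chain carbon gives a number 0.8 percentage points higher from compound 2 to compound 4 (within the scatter), so a side chain of 12 heavy atoms with a hydrogen-bond donor and acceptors reads the same, within the scatter, as one of 4 heavy atoms with neither. The comparison with the guanidine-bearing side chain of compound 1 gives a number 2.4 percentage points lower from compound 1 to compound 4 (within the scatter), so the position has now seen three different side chains on this core without any step beyond the scatter. No measurement here explains why these changes leave the number unmoved.

On these data alone, it remains open whether a free amine at the end of the butyl chain, or a carboxylic acid at the same place, would move the number beyond the scatter. A small group such as methyl on this carbon also remains untested among the compounds shown.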